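The source may hold more compounds than are shown below. What is called first, only, known or untested is meant among the compounds shown, and "the series" means these compounds.

Measured compounds in an in vitro functional assay on 1321-N1 cells for agonist activity at P2Y purinoceptor 4 (Homo sapiens), read by scintillation proximity assay and inositol phosphate accumulation; a lower number here means that less compound is needed, a higher number that more compound is needed for the effect:
compound 1 `Nc1nc(=O)ccn1[C@@H]1O[C@H](COP(=O)(O)OP(=O)(O)O)[C@@H](O)[C@H]1O`: >= 100000 nM
compound 2 `CCCSc1nc(=O)ccn1[C@@H]1O[C@H](COP(=O)(O)OP(=O)(O)O)[C@@H](O)[C@H]1O`: 4900 nM

The value of compound 1 is a limit of this assay, not a number; it sits at the limit of >= 100000 nM in this assay, at which 1 of the 2 values shown sits. Within the data shown here, compound 2 therefore stands as the only numbered value, with no measured neighbour to rank it against. Among the measured compounds shown here, the single measured step, an at least 20-fold lower number from compound 1 to compound 2 (1.30 log units; beyond the scatter), is large, but it replaces amino with propylsulfanyl and so speaks only to the presence of the sulfanyl chain, not to its length or shape.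

Compound 3 `O=c1ccn([C@@H]2O[C@H](COP(=O)(O)OP(=O)(O)O)[C@@H](O)[C@H]2O)c(SCc2ccccc2)n1` differs from compound 2 by phenyl in place of ethyl on a saturated chain carbon bound to a sulfur. For the measured compounds named here, no measured step varies the group on the sulfur, so the expectation rests on the sulfanyl chain being kept. The step of a 1.4-fold lower number from compound 2 to compound 3 (0.15 log units; within the scatter) is expected to stay within the usual scatter. Compound 3 is estimated at 3500 nM, with a range of 700 nM to 17000 nM.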

Compound 3, half-maximal effective concentration: 5980 nM
Compound 3: the middle estimate sits 1.7-fold (0.23 log units) below what was measured; the range from low to high includes it.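

In this assay, phenyl in place of ethyl on the saturated chain carbon bound to a sulfur gives a 1.2-fold higher number from compound 2 to compound 3 (0.09 log units; within the scatter), so propylsulfanyl and benzylsulfanyl read alike here, and this place takes a six-membered aromatic ring of carbon only without a step beyond the scatter. The step of an at least 16-fold lower number from compound 1 to compound 3 (1.22 log units; beyond the scatter) leaves amino for benzylsulfanyl, so the large step away from amino no longer rests on propylsulfanyl alone. Compound 1 gives >= 100000 nM, which is a limit and not a number: the limit of >= 100000 nM in this assay, at which 1 of the 3 values shown sits.

Still open, as far as these compounds go, is whether the sulfur itself matters, as a propoxy group or a plain butyl chain on the same aromatic carbon would test. Also open, from the compounds shown here alone, is whether a chlorine or methoxy group on the phenyl ring, or a longer chain on the sulfur, would move the number beyond the scatter.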